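Amide Replacement on the Sulfonamide Core at GPR27

The compounds below may be only part of what the source reports. "The series", "measured", "known", "first", "only" and "open" are said of these compounds alone.

Measured compounds:
compound 1, `CN(c1ccccc1)S(=O)(=O)c1ccc(NC(=O)c2ccc(Cl)cc2Cl)cc1`, 2570 nM
compound 2, `Cc1cc(Br)ccc1C(=O)Nc1ccc(S(=O)(=O)Nc2ccccc2)cc1`, 851 nM

Of the compounds shown here, two have been measured in a functional assay on HEK293 cells for agonist activity at probable G-protein coupled receptor 27 (Homo sapiens), read by a luciferase reporter and beta-arrestin recruitment, with a stated time of 10 min; a higher number here means that more compound is needed for the effect, a lower number that less compound is needed. Compound 1 gives 2570 nM, and compound 2 gives 851 nM. Compound 2 therefore stands at the lower of the two numbers, and the gap to compound 1 is beyond the usual scatter of repeated measurements. The two compounds differ in more than one place, so what separates them cannot be laid on a single change.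

Compound 3 is `N#Cc1ccc(C(=O)Nc2ccc(S(=O)(=O)Nc3ccccc3)cc2)c(F)c1`. It differs from compound 2 in one place only: 4-cyano-2-fluorophenyl in place of 4-bromo-2-methylphenyl on a carbonyl carbon. For the measured compounds named here, no measured pair in this set isolates a change of this kind, so there is no prior step to lean on, and the expectation for compound 3 rests on the value of compound 2 alone. For compound 3 the step of a 1.8-fold higher number from compound 2 to compound 3 (0.25 log units; within the scatter) is expected to be modest, somewhat toward a higher number, but it may well fall within the scatter. On that basis compound 3 is estimated at 1500 nM in this assay, with a range from 400 nM to 6000 nM.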

Compound 3, half-maximal effective concentration: 229 nM
Compound 3: middle estimate off by 6.6-fold (0.82 log units), on the high side; the measured number lies below the stated range.
By their numbers in this assay, from the lowest: compound 3; then compound 2; then compound 1.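

The aryl group on the carbonyl carbon, whose other neighbour is the amide-type nitrogen, emerges as a position that responds in this assay: with the rest of the molecule held constant, 4-cyano-2-fluorophenyl in place of 4-bromo-2-methylphenyl gives a 3.7-fold lower number from compound 2 to compound 3 (0.57 log units; beyond the scatter). For the compounds shown here, this is the first change in the set that can be read on its own, and it shows that the number can move beyond the scatter while the six-membered aromatic ring of carbon stays in place and only the groups on it are exchanged. No measurement shown here bears on why the number moved.

As far as these compounds go, the nitrile and the fluorine enter together and the bromine and the methyl leave together, so it remains open which of these exchanges carries the step, and whether a carboxylic acid, an amine or a methoxy group on that ring would hold the lower number. The methyl on the sulfonamide nitrogen of compound 1 also remains unresolved, as compound 1 differs from the other two compounds in more than one place.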